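Trifluoromethoxy in Place of Fluoro on Compound 3

This account rests on a few compounds, and the source may have more. Where it says the series, first, only, none or still open, it means among the compounds named here.

Three measured compounds share one core and differ only on the attached aromatic ring. Among the measured compounds shown here, in a functional assay on CHO cells for inhibition of metabotropic glutamate receptor 5 (Rattus norvegicus), read by FLIPR and calcium flux (on this read-out lower numbers stand for stronger inhibition and higher numbers for weaker inhibition), compound 1 `COCc1cccc(-c2ccc3ccc(C)nc3c2)c1` gives 5800 nM and compound 2 `Cc1ccc2ccc(-c3cccc(O)c3)cc2n1` gives 19000 nM; the single measured step, a 3.3-fold higher number from compound 1 to compound 2 (0.52 log units; beyond the scatter), is the only one of its kind here. Compound 3 `Cc1ccc2ccc(-c3cc(F)cc(C#N)c3)cc2n1` gives 0.8 nM, the lowest of the three numbers by a wide margin. Compound 4 `Cc1ccc2ccc(-c3cc(C#N)cc(OC(F)(F)F)c3)cc2n1` carries trifluoromethoxy in place of fluoro on an aromatic carbon. For the measured compounds named here, no measured step involves a trifluoromethoxy or a fluoro group, so the only guide to its size is a 3.3-fold higher number from compound 1 to compound 2 (0.52 log units; beyond the scatter), a different swap that moved the number modestly. A modest rise is expected, a 3.8-fold higher number from compound 3 to compound 4 (0.57 log units; beyond the scatter). Compound 4 is therefore expected to give 3 nM, within 0.5 nM to 20 nM.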

Compound 4, half-maximal inhibitory concentration: 75 nM
Beside the measured number, compound 4's estimate is 25-fold (1.40 log units) below it; measured number outside the range, above it.
By their numbers in this assay, from the lowest: compound 3; then compound 4; then compound 1; then compound 2.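

In this assay, trifluoromethoxy in place of fluoro, on a ring that also holds a cyano group, gives a 94-fold higher number from compound 3 to compound 4 (1.97 log units; beyond the scatter). Among the compounds shown here, this is the first step at this position, and it shows that the position is sensitive to the group placed there: exchanging this one group produces a large change. The data shown offer no measurement that explains the change.

The compounds shown leave open how chloro, methoxy or an amine would compare with fluoro here. They also leave open whether the oxygen or the added fluorines of trifluoromethoxy drive the change.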